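Swapping trifluoromethyl for fluoro on compound 3

This account rests on a few compounds, and the source may have more. Where it says the series, first, only, none or still open, it means among the compounds named here.

Measured in an ADME assay on HepG2 cells (Homo sapiens) for cytotoxicity, with a stated time of 72 h; on this read-out lower numbers stand for an effect already at smaller amounts and higher numbers for an effect only at larger amounts of compound:
- compound 1 `Cc1cc(NC(=O)Nc2ccc(F)cc2)c2ccccc2n1` gives > 25000 nM
- compound 2 `Cc1cc(NC(=O)Nc2ccc(O)cc2)c2ccccc2n1` gives > 25000 nM
- compound 3 `Cc1cc(NC(=O)Nc2ccccc2C(F)(F)F)c2ccccc2n1` gives > 25000 nM

All readings so far sit on one limit and none is a number: the limit of > 25000 nM in this assay, at which 3 of the 3 values shown sit. Compound 3 therefore stands only at a limit, > 25000 nM. Compound 4 `Cc1cc(NC(=O)Nc2ccccc2F)c2ccccc2n1` has fluoro in place of trifluoromethyl on an aromatic carbon. For the measured compounds named here, the one measured step bearing on this, a step that the two limits leave unreadable from compound 1 to compound 2, also exchanges one group on an aromatic carbon but gives no size to carry over. No step beyond the scatter is expected in this assay, in either direction, and another limit is the likeliest result. The expected change is a step that the limit leaves unreadable from compound 3 to compound 4. For compound 4 the estimate is 30000 nM, with an expected range from 18000 nM to 60000 nM.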

Compound 4, half-maximal effective concentration: > 25000 nM
Compound 4 gave a limit, no number (the forecaster's own chance of this, stated with the estimate: 90%); the middle value is on the limit's open side.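

For the compounds shown here, no step to compound 4 can be read from compound 1, compound 2 or compound 3, since all four compounds give only a limit: the limit of > 25000 nM in this assay, at which 4 of the 4 values shown sit.

Still open, from the compounds shown here alone, is whether this assay separates these compounds at all, as none of them has a number.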